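The source may hold more compounds than are shown below. What is called first, only, known or untested is meant among the compounds shown, and "the series" means these compounds.

Measured in a functional assay on HCT-116 cells (Homo sapiens) for inhibition, read by sulforhodamine B assay, with a stated time of 48 h, tested at 50 uM; on this read-out higher numbers stand for more inhibition of growth at the one concentration tested and lower numbers for less inhibition of growth:
compound 1 `COc1cc(/C=C/C(=O)/C=C/c2cccc3ccccc23)ccc1OCc1cn(CCOc2cc(=O)oc3ccccc23)nn1`: 83%
compound 2 `COc1cc(/C=C/C(=O)/C=C/c2cc(OC)c(OC)c(OC)c2)ccc1OCc1cn(CCOc2cc(=O)oc3ccccc23)nn1`: 89%
compound 3 `COc1ccc(/C=C/C(=O)/C=C/c2ccc(OCc3cn(CCOc4cc(=O)oc5ccccc45)nn3)c(OC)c2)cc1OC`: 82%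

Compound 3, at 82%, cannot be told apart from compound 1 or compound 2, since its steps to both lie within the scatter. Compound 4 `COc1cc(/C=C/C(=O)/C=C/c2ccccc2)ccc1OCc1cn(CCOc2cc(=O)oc3ccccc23)nn1` differs from compound 3 by phenyl in place of 3,4-dimethoxyphenyl on a double-bonded chain carbon bound to a double-bonded chain carbon. Going by the values given here, two measured steps bear on this change: a number 7 percentage points lower from compound 2 to compound 3 (within the scatter), with hydrogen in place of methoxy on an aromatic carbon, and a number 1 percentage points lower from compound 1 to compound 3 (within the scatter), which exchanges the same group. Both stay within the scatter, so no step beyond it is expected in this assay. The expected step is small, a number 2 percentage points lower from compound 3 to compound 4 (within the scatter). Compound 4 is estimated at 80%, with an expected range of 68% to 90%.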

Compound 4, percent growth inhibition at one concentration: 56%
For compound 4 the middle estimate is 24 percentage points above the measured one; the whole stated range lies above it.
By their numbers in this assay, from the lowest: compound 4; then compounds 3, 1 and 2 (each within the scatter of the next).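

With phenyl on a double-bonded chain carbon bound to a double-bonded chain carbon, this assay gives a number 26 percentage points lower from compound 3 to compound 4 (beyond the scatter) and a number 33 percentage points lower from compound 2 to compound 4 (beyond the scatter) and also a number 27 percentage points lower from compound 1 to compound 4 (beyond the scatter) in this series. So this position does not accept every aromatic group alike: 3,4-dimethoxyphenyl, 3,4,5-trimethoxyphenyl and naphthalen-1-yl could not be told apart, and only bare phenyl separates from them. Nothing available explains this loss.

Still open, on these data alone, is whether a phenyl carrying a single methoxy would behave like compound 3 or like compound 4. Also open, as far as these compounds go, is how a phenyl bearing an amine or a carboxylic acid would fare at this position.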